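The compounds below may be only part of what the source reports. "The series", "measured", "known", "first", "only" and "open" are said of these compounds alone.

Measured so far:
compound 1 `Cc1cccc(C(=O)Nc2cc(Cl)cc3c(=O)cc(C(=O)O)oc23)c1`, in an assay on CHO cells for agonist activity at G protein-coupled receptor GPR35 (Rattus norvegicus), read by a beta-galactosidase reporter and beta-arrestin recruitment, with a stated time of 90 min (a higher number here means that more compound is needed for the effect, a lower number that less compound is needed), compound 1 gives 2100 nM
compound 2 `Cc1cccc(C(=O)Nc2cccc3c(=O)cc(C(=O)O)oc23)c1`, in this assay compound 2 gives 2750 nM

Compound 2 has the highest of the two numbers, with compound 1 nearest by a 1.3-fold higher number from compound 1 to compound 2 (0.12 log units; within the scatter), a difference within the scatter. Compound 3 `O=C(O)c1cc(=O)c2cccc(NC(=O)C3CCCCC3)c2o1` differs from compound 2 by cyclohexyl in place of 3-methylphenyl on a carbonyl carbon. Among the compounds with values here, the only measured step, a 1.3-fold higher number from compound 1 to compound 2 (0.12 log units; within the scatter), concerns a different place on the shared core and does not bear on this change, so no direction can be read from it. For compound 3 in this assay the expected number is 3500 nM, range 1200 nM to 12000 nM. This expectation corresponds to a 1.3-fold higher number from compound 2 to compound 3 (0.10 log units; within the scatter).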

Compound 3, half-maximal effective concentration: 1200 nM
Estimate against measurement, compound 3: 2.9-fold (0.46 log units) above, within the range that was stated.
By their numbers in this assay, from the lowest: compounds 3, 1 and 2 (each within the scatter of the next, the first and the last beyond it).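

Within the data shown here, at the carbonyl carbon, a non-aromatic ring is tolerated: cyclohexyl in place of 3-methylphenyl gives a 2.3-fold lower number from compound 2 to compound 3 (0.36 log units; beyond the scatter) in this assay, the only step so far that lies beyond the scatter, though a modest one. The earlier chloro-to-hydrogen step concerned another place on the shared core and said nothing about this group. No available evidence bears on the origin of this step.

Still open, on these data alone, is how a cyclopentyl group, a straight hexyl chain or a phenyl ring bearing a carboxylic acid would compare with cyclohexyl at this carbonyl carbon. Also open, as far as these compounds go, is whether chloro on the shared core would change the number with cyclohexyl in place.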